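The source may hold more compounds than are shown below. What is called first, only, known or untested is meant among the compounds shown, and "the series" means these compounds.

Compound 1 `COc1nc(N)nc2c1c(-c1ccccc1)cn2[C@@H]1O[C@H](CO)[C@@H](O)[C@H]1O` and compound 2 `COc1nc(N)nc2c1c(-c1cccs1)cn2[C@@H]1O[C@H](CO)[C@@H](O)[C@H]1O` share one core, while compound 3 `CNc1ncnc2c1c(-c1ccccc1)cn2[C@@H]1O[C@H](CO)[C@@H](O)[C@H]1O` is built on another; the difference between the two cores is not broken down here. In a functional assay on K562 cells (Homo sapiens), read by MTT assay, with a stated time of 72 h (a higher number here means a weaker inhibitor, a lower number a stronger inhibitor), compound 1 gives only a limit, > 20000 nM. Compound 2 likewise gives only a limit in this assay, > 20000 nM. Compound 3 also reaches only a limit in this assay, > 20000 nM. The change thiophen-2-yl in place of phenyl on an aromatic carbon therefore makes a step that the two limits leave unreadable from compound 1 to compound 2. Compound 4 `CNc1ncnc2c1c(-c1cccs1)cn2[C@@H]1O[C@H](CO)[C@@H](O)[C@H]1O` arises from compound 3 by the same kind of change, (thiophen-2-yl in place of phenyl on an aromatic carbon); the surroundings differ only in that the ring atom is said to bear a 3,4-dihydroxy-5-(hydroxymethyl)oxolan-2-yl group in one case and a group of 9 heavy atoms in the other. Because the limit of > 20000 nM in this assay, at which 3 of the 3 values shown sit, holds for every measured value, the step expected is a step that the limit leaves unreadable from compound 3 to compound 4, and a further limit is the most likely outcome. Compound 4 is accordingly estimated at 30000 nM, within 10000 nM and 100000 nM.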

Compound 4, half-maximal inhibitory concentration: > 20000 nM
Compound 4: no number, only a limit; the forecaster's own chance of this, stated with the estimate: 85%; the middle value is on the limit's open side.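

Compound 3 and compound 4 both give only a limit in this assay, so the step between them cannot be read. The compounds shown leave open what thiophen-2-yl in place of phenyl does to potency wherever a readable value exists.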